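Three Inactive Esters and Nitrile, and a Diethylamide to Come

The compounds below may be only part of what the source reports. "The series", "measured", "known", "first", "only" and "open" are said of these compounds alone.

compound 1 `CCOC(=O)Cn1c(=O)c(-c2ccc(OC)cc2)cc2c(OC)cc(OC)cc21`: 10000 nM
compound 2 `COc1ccc(-c2cc3c(OC)cc(OC)cc3n(CC#N)c2=O)cc1`: 10000 nM
compound 3 `COC(=O)CCn1c(=O)c(-c2ccc(OC)cc2)cc2c(OC)cc(OC)cc21`: 10000 nM

In a functional assay on A-427 cells (Homo sapiens) for cytotoxicity, read by colorimetric assay and MTT assay (on this read-out lower numbers stand for stronger inhibition and higher numbers for weaker inhibition), level with compound 1 and compound 2, compound 3 gives 10000 nM. Compound 4 `CCN(CC)C(=O)CCn1c(=O)c(-c2ccc(OC)cc2)cc2c(OC)cc(OC)cc21` carries diethylamino in place of the methoxy of compound 3 on a carbonyl carbon, so methoxycarbonyl becomes diethylcarbamoyl: diethylamino in place of methoxy on a carbonyl carbon. The measured steps all altered this same chain: no change at the digits printed from compound 1 to compound 2 (within the scatter), no change at the digits printed from compound 1 to compound 3 (within the scatter) and no change at the digits printed from compound 2 to compound 3 (within the scatter). Each stayed within the scatter, though none introduces diethylcarbamoyl, so the evidence is indirect. No change beyond the scatter is therefore expected in this assay. The expected step is no change at the digits printed from compound 3 to compound 4 (within the scatter). The value estimated for compound 4 is 10000 nM, with an expected range of 5000 nM to 20000 nM.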

Compound 4, half-maximal inhibitory concentration: 10000 nM
Estimate against measurement, compound 4: no gap at the digits printed; measured number inside the range.
By their numbers in this assay, from the lowest: compounds 1, 2, 3 and 4 (each within the scatter of the next).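

In this assay this carbonyl carbon takes diethylamino in place of methoxy with no shift (no change at the digits printed from compound 3 to compound 4 (within the scatter)), so an amide now stands level with the esters and the nitrile on this chain. The comparisons with the nitrile and the ethyl ester read the same (no change at the digits printed from compound 2 to compound 4 (within the scatter) and no change at the digits printed from compound 1 to compound 4 (within the scatter)). Still open is whether a carboxylic acid or a primary amine at the end of this chain would move the value at all, since no change shown here separates any two compounds. Nothing available explains this flat result.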